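A few compounds are considered here, and "the series" means these few. Any claim that something is new, unique, unknown or untested is made for them only; others in the source may bear on it.

In a functional assay on HT-29 cells (Homo sapiens) for antiproliferative activity, read by sulforhodamine B assay, with a stated time of 72 h (a lower number here means a stronger inhibitor, a higher number a weaker inhibitor), compound 2 `S=C(N/N=C/c1ccc2ccccc2n1)Nc1cccc(Br)c1` gives 58900 nM. Among the compounds with values here, compound 1 `NC(=S)N/N=C/c1ccc2ccccc2n1` gives 100000 nM in this assay, and the only measured step, a 1.7-fold lower number from compound 1 to compound 2 (0.23 log units; within the scatter), is within the scatter, so compound 2 stands among two numbers that cannot be ordered. Compound 3 `S=C(NCc1ccccc1)N/N=C/c1ccc2ccccc2n1` differs from compound 2 by benzyl in place of 3-bromophenyl on an amide-type nitrogen. Within the data shown here, no measured step swaps one group for another on that nitrogen, and the one step that touches it stayed within the scatter. The step of a 1.0-fold higher number from compound 2 to compound 3 (0.01 log units; within the scatter) is therefore expected to show no change beyond the scatter. Compound 3 is estimated at 60000 nM, with a range from 20000 nM to 150000 nM.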

Compound 3, half-maximal inhibitory concentration: 75700 nM
For compound 3 the middle estimate is 1.3-fold (0.10 log units) below the measured one, within the range that was stated.
By their numbers in this assay, from the lowest: compounds 2, 3 and 1 (each within the scatter of the next).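

In this assay, within the data shown here, the first swap of one group for another on the amide-type nitrogen gives a 1.3-fold higher number from compound 2 to compound 3 (0.11 log units; within the scatter) and benzyl in place of hydrogen there gives a 1.3-fold lower number from compound 1 to compound 3 (0.12 log units; within the scatter) so neither change can be told from repeated measurement. Hydrogen, 3-bromophenyl and benzyl on this nitrogen therefore cannot be ordered, whether or not the group carries bromine. No evidence is available to explain this result.

Going by these compounds, whether a longer chain, an amine or a carboxylic acid on this nitrogen would move the number beyond the scatter remains open. So does the effect of any change to the shared core.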